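The source may report more compounds than this note shows. Statements on the series, on what has been measured and on what is new or still open speak of the compounds shown alone.

In a functional assay on the whole organism (strain ICR) for inhibition, with Mus musculus as the target, read by scintillation counting, with a stated time of 4 h, at a dose of 10 mg/kg by the oral route (on this read-out higher numbers stand for more inhibition at the one dose given (going by the name of the read-out) and lower numbers for less inhibition), compound 3 `Cn1c(-c2ccccc2)nnc1C1(c2ccc(Cl)cc2)CCC1` gives 29%, the lowest of the three measured values. Compound 1 `Cn1c(-c2ccc(N)cc2Cl)nnc1C1(c2ccc(Cl)cc2)CCC1` gives 90% in this assay, and compound 2 `Cn1c(-c2ccc(-c3cnccn3)cc2F)nnc1C1(c2ccc(Cl)cc2)CCC1` gives 91%. Among the measured compounds shown here, the one measured step that runs between single changes, a number 61 percentage points lower from compound 1 to compound 3 (beyond the scatter), shows that stripping the substituents from the ring attached to the shared core cost a large share of the effect.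

Compound 4 `Cn1c(-c2ccc(C(=O)NC(C)(C)C)cc2)nnc1C1(c2ccc(Cl)cc2)CCC1` is built from compound 3 by the change ((tert-butyl)carbamoyl in place of hydrogen on an aromatic carbon). The step from compound 1 to compound 3 bears on this, since it shows that a substituted ring at that position, as in compound 1 and in compound 2, went with high inhibition, whereas the bare ring of compound 3 did not. The new group differs from those in compound 1 and compound 2, so the size of any recovery is uncertain, but a rise beyond the scatter is expected, a number 36 percentage points higher from compound 3 to compound 4 (beyond the scatter). Compound 4 is therefore estimated at 65%, with a likely range from 35% to 90%.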

Compound 4, a percentage reported as inhibition, in the whole organism at one dose (the size of the read-out at that dose, not a potency): 71%
Beside the measured number, compound 4's estimate is 6 percentage points below it, within the range that was stated.
By their numbers in this assay, from the lowest: compound 3; then compound 4; then compounds 1 and 2 (each within the scatter of the next).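

In this assay the (tert-butyl)carbamoyl group brings a number a number 42 percentage points higher from compound 3 to compound 4 (beyond the scatter) on its own, so one group on an aromatic carbon, para to a large group, is enough to raise the inhibition by a large amount. The earlier step from the 4-amino-2-chlorophenyl ring to the bare phenyl ring changed two substituents at once and could not show whether a single group would do. No measurement available here explains why this group has such an effect.

Going by these compounds, what remains open is which part of the new group matters, the carbonyl, the amide hydrogen or the tert-butyl. A carboxylic acid, a plain amine or a methyl amide in the same place would help to separate these parts.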